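The source may hold more compounds than are shown below. What is called first, only, known or untested is meant among the compounds shown, and "the series" means these compounds.

Working notes on the series. Compound 1 `Cn1c(/C=C/C(=O)c2cccc(O)c2)cc(Br)c1Br`, compound 2 `Cn1c(/C=C/C(=O)c2ccc(O)cc2O)cc(Br)c1Br` and compound 3 `Cn1c(/C=C/C(=O)c2ccc(O)cc2)cc(Br)c1Br` have been run in a functional assay on Caco-2 cells (Homo sapiens) for cytotoxicity, read by MTT assay, with stated times of 6 h and 48 h; on this read-out higher numbers stand for weaker inhibition and lower numbers for stronger inhibition; compound 4 `Cn1c(/C=C/C(=O)c2cc(O)ccc2O)cc(Br)c1Br` has not. In this assay compound 3 gives 6000 nM. In this assay compound 2 gives 3530 nM. For compound 1 the read-out in this assay is a limit and not a number, >= 100000 nM (the limit of >= 100000 nM in this assay, at which 1 of the 3 values shown sits).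

The measured change from compound 3 to compound 2 is hydroxy in place of hydrogen on an aromatic carbon and gave a 1.7-fold lower number from compound 3 to compound 2 (0.23 log units; within the scatter). Compound 4 would arise from compound 1 by hydroxy in place of hydrogen on an aromatic carbon, the same kind of change; the places differ in that the entering hydroxy stands meta to a hydroxy group in compound 2 but para to a hydroxy group in compound 4. Compound 1 and compound 3 have the same atoms joined differently, and the difference between the two cores is not broken down here. Compound 3 gives a number in this assay, whereas compound 1 gives only a limit.

Because the earlier step of a 1.7-fold lower number from compound 3 to compound 2 (0.23 log units; within the scatter) lay within the scatter, little movement is expected from the same kind of change on compound 1, but the starting point is only a limit (the limit of >= 100000 nM in this assay, at which 1 of the 3 values shown sits), so the estimate is broad. Compound 4 is expected to give about 30000 nM in this assay, somewhere between 5000 nM and 150000 nM. That estimate for compound 4 corresponds to an expected step of an at least 3.3-fold lower number from compound 1 to compound 4 (0.52 log units; beyond the scatter), with a fair chance that only a limit is reported again.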

Compound 4, half-maximal inhibitory concentration: >= 100000 nM
Compound 4: only a limit was reported; the forecaster's own chance of this, stated with the estimate: 40%; at least 3.3-fold (0.52 log units) between middle value and limit.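

No step can be read from compound 1 to compound 4 in this assay, because both compounds give only a limit and neither gives a number: the limit of >= 100000 nM in this assay, at which 2 of the 4 values shown sit.

The compounds shown leave open whether hydroxy in place of hydrogen on an aromatic carbon, para to a hydroxy group, changes the read-out at all, and whether compound 1 and compound 4 differ.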